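Angiotensin-related pyrimidinone series: a thioamide variant is anticipated

A few compounds are considered here, and "the series" means these few. Any claim that something is new, unique, unknown or untested is made for them only; others in the source may bear on it.

Measured compounds:
Compound 1, `CCCc1nc(C)c(CC(=O)O)c(=O)n1Cc1ccc(-c2ccccc2-c2nnn[nH]2)cc1` — in an in vivo functional assay on the whole organism for inhibition, with Rattus norvegicus as the target (on this read-out lower numbers stand for an effect already at smaller amounts and higher numbers for an effect only at larger amounts of compound), compound 1 gives "not determined" (no result reported), so no number is reported for it.
Compound 2, `CCCc1nc(C)c(CC(=O)N(CC)CC)c(=O)n1Cc1ccc(-c2ccccc2-c2nnn[nH]2)cc1` — in this assay compound 2 gives "not determined" (no result reported), so no number is reported for it either.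
Compound 3, `CCCCc1nc(C)c(CC(=O)N2CCOCC2)c(=O)n1Cc1ccc(-c2ccccc2-c2nnn[nH]2)cc1` — in this assay compound 3 gives 0.018 mg/kg.

The study rests on a single number. In this assay compound 3 gives 0.018 mg/kg. For the measured compounds named here, compound 1 and compound 2 share the core of compound 3 but carry no reported value, so compound 3 is the only point of reference; no step between measured compounds can be drawn, and nothing is known about how a change at the side chain shifts the dose.

Compound 4, `CCCCc1nc(C)c(CC(=S)N2CCCCCC2)c(=O)n1Cc1ccc(-c2ccccc2-c2nnn[nH]2)cc1`, is the compound to be measured next. It differs from compound 3 in one place: a group of 9 heavy atoms (7 carbon, 1 nitrogen, 1 sulfur; one seven-membered non-aromatic ring with 1 hetero atom) in place of a group of 8 heavy atoms (5 carbon, 1 nitrogen, 2 oxygen; one six-membered non-aromatic ring with 2 hetero atoms), on a saturated chain carbon bound to an aromatic carbon. The change sits on a saturated chain carbon bound to an aromatic carbon, with a group of 9 heavy atoms (7 carbon, 1 nitrogen, 1 sulfur; one seven-membered non-aromatic ring with 1 hetero atom) entering and a group of 8 heavy atoms (5 carbon, 1 nitrogen, 2 oxygen; one six-membered non-aromatic ring with 2 hetero atoms) leaving.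

Going by the values given here, with no measured step to lean on, the expected step of a 1.7-fold higher number from compound 3 to compound 4 (0.22 log units; within the scatter) in this assay is a small move toward a larger dose, of a size that may not exceed the usual scatter. Compound 4 is therefore estimated at 0.03 mg/kg, within a range from 0.008 mg/kg to 0.12 mg/kg.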

Compound 4, dose for half-maximal effect: 0.034 mg/kg
Beside the measured number, compound 4's estimate is 1.1-fold (0.05 log units) below it; the measured number falls inside the stated range.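

In this assay, for the compounds shown here, the first step that can be read at this position is a 1.9-fold higher number from compound 3 to compound 4 (0.28 log units; within the scatter). Replacing (morpholin-4-yl)carbonyl with the sulfur-bearing group with one seven-membered non-aromatic ring, on a saturated chain carbon bound to an aromatic carbon, therefore leaves compound 3 and compound 4 indistinguishable on this read-out, showing that this single pair keeps its dose despite a simultaneous exchange of ring and of oxygen for sulfur. Nothing available bears on why the two compounds read alike.

Because ring and sulfur change together, the compounds shown leave open what each exchange contributes alone, which a carbonyl group carrying the same seven-membered ring or a thiocarbonyl group carrying the morpholin-4-yl ring would separate. They also leave open whether the same holds for other groups at this place, such as a piperidin-1-yl amide or a simple primary amide, and how the carboxylic acid of compound 1 and the diethylamide of compound 2 would compare, since neither has a number to read.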